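Swapping the Indole for an Aminomethoxyphenyl Group

The compounds below may be only part of what the source reports. "The series", "measured", "known", "first", "only" and "open" are said of these compounds alone.

Compound 1 `COc1cc(-c2ccnc3cc(-c4ccc5c(ccn5C)c4)nn23)cc(OC)c1OC`: 19 nM
Compound 2 `COc1cc(-c2ccnc3cc(-c4cn(C(=O)OC(C)(C)C)c5ccccc45)nn23)cc(OC)c1OC`: 3770 nM
Compound 3 `COc1cc(-c2ccnc3cc(-c4cccc5c4ccn5CO)nn23)cc(OC)c1OC`: 456 nM

All three compounds share one core and were tested in a functional assay on HeLa cells (Homo sapiens) for inhibition, read by CCK-8 assay, with a stated time of 48 h; a lower number here means a stronger inhibitor, a higher number a weaker inhibitor. Compound 1 gives 19 nM, the lowest of the three numbers. Compound 3, the nearest, gives 456 nM, a gap beyond the scatter, and compound 2 gives 3770 nM, further still. Compound 1 is therefore the strongest inhibitor among the three measured.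

Compound 4 `COc1ccc(-c2cc3nccc(-c4cc(OC)c(OC)c(OC)c4)n3n2)cc1N` has not yet been measured in this assay. It differs from compound 1 in one place: 3-amino-4-methoxyphenyl in place of 1-methyl-1H-indol-5-yl on an aromatic carbon. The group that leaves carries two fused rings; the group that enters is a single ring bearing an amino and a methoxy substituent.

Within the data shown here, no step between two measured compounds matches this exchange, so the expectation rests on compound 1 alone. Because compound 1 gives 19 nM with the indole in this position, and a single ring with one hydrogen-bond donor and two acceptors replaces it, a modest loss of potency, about the size of the scatter, is expected: the step from compound 1 to compound 4 is estimated at a 1.8-fold higher number from compound 1 to compound 4 (0.27 log units; within the scatter). Compound 4 is expected to give 35 nM, within a range from 8 nM to 150 nM.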

Compound 4, half-maximal inhibitory concentration: 283 nM
Beside the measured number, compound 4's estimate is 8.1-fold (0.91 log units) below it; the measured number lies above the stated range.
By their numbers in this assay, from the lowest: compound 1; then compounds 4 and 3 (each within the scatter of the next); then compound 2.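

In this assay, putting 3-amino-4-methoxyphenyl in place of 1-methyl-1H-indol-5-yl on this aromatic carbon gives a 15-fold higher number from compound 1 to compound 4 (1.17 log units; beyond the scatter), a large step and the first one here that reads a change in a single place. It shows that this position is not indifferent to the group it carries: the single ring with its amino and methoxy substituents does not keep the potency seen with the fused two-ring group of compound 1. No supporting measurement accounts for this loss, so the step records its size and leaves its cause unexplained.

Several things change at once in this exchange: the second ring goes, and an amino group and a methoxy group arrive, so the compounds shown leave open which of these changes carries the loss. A plain phenyl ring, a phenyl ring bearing only an amino group or only a methoxy group, and an indole with a hydrogen in place of the N-methyl group would each separate one of these changes from the others.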